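Trimming the Urea Tail of Compound 1

The source may report more compounds than this note shows. Statements on the series, on what has been measured and on what is new or still open speak of the compounds shown alone.

Compound 1 `COc1ncc(-c2ccc3nc(NC(=O)NCCN(C)C)sc3c2)cc1NS(=O)(=O)c1ccc(F)cc1` is one of two measured compounds here. In a functional assay on U-87MG ATCC cells for antiproliferative activity against U-87 MG (Homo sapiens), read by MTT assay, with a stated time of 72 h (a lower number here means a stronger inhibitor, a higher number a weaker inhibitor), compound 1 gives 1020 nM, the higher of the two numbers. Compound 2 `CCN(CC)CCNC(=O)Nc1nc2ccc(-c3cnc(OC)c(NS(=O)(=O)c4ccc(C)cc4)c3)cc2s1` gives 360 nM in this assay, a gap beyond the usual scatter. Compound 3 `CNC(=O)Nc1nc2ccc(-c3cnc(OC)c(NS(=O)(=O)c4ccc(F)cc4)c3)cc2s1` has not been measured. It differs from compound 1 by hydrogen in place of (dimethylamino)methyl on a saturated chain carbon bound to an amide-type nitrogen. For the measured compounds named here, no measured pair shows this change, so the expected step of a 1.6-fold higher number from compound 1 to compound 3 (0.20 log units; within the scatter) is small, toward a weaker inhibitor, and may well sit within the scatter. Compound 3 is therefore estimated at 1600 nM, within a range from 500 nM to 5000 nM.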

Compound 3, half-maximal inhibitory concentration: 1230 nM
Estimate against measurement, compound 3: 1.3-fold (0.11 log units) above; measured number inside the range.
By their numbers in this assay, from the lowest: compound 2; then compounds 1 and 3 (each within the scatter of the next).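

In this assay, shortening 2-(dimethylamino)ethyl to methyl on the urea gives a 1.2-fold higher number from compound 1 to compound 3 (0.08 log units; within the scatter). In this one pair, then, the dimethylamino end of the tail can be removed without a change beyond the scatter. Nothing available here bears on why the step is so small. On these data alone, what stays open is how a carboxylic acid, a morpholine or a longer chain ending in an amine would behave at this place, since only the methyl end has been compared with the 2-(dimethylamino)ethyl tail.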